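This account rests on a few compounds, and the source may have more. Where it says the series, first, only, none or still open, it means among the compounds named here.

Measured in a functional assay (muscle tissue) with Cavia porcellus as the target (on this read-out higher numbers stand for an effect only at larger amounts of compound and lower numbers for an effect already at smaller amounts), so far:
- compound 1 `COC(=O)C1=C(C)N=C(C)/C(=C(\O)OC)C1c1ccc(Cl)cc1` gives 8130 nM
- compound 2 `C=Cc1ccccc1C1C(C(=O)OC)=C(C)N=C(C)/C1=C(\O)OC` gives 4.47 nM

Compound 2 has the lower of the two numbers. Not yet measured is compound 3 `COC(=O)C1=C(C)N=C(C)/C(=C(\O)OC)C1c1ccc(Cl)cc1Cl` with 2,4-dichlorophenyl in place of 2-vinylphenyl on a saturated ring carbon and the rest unchanged. Among the measured compounds shown here, the only measured step that bears on this is a 1800-fold lower number from compound 1 to compound 2 (3.26 log units; beyond the scatter) and it is large. For the measured compounds named here, the new group combines the 4-chloro pattern of compound 1 at 8130 nM with the 2-substitution of compound 2 at 4.47 nM and no measured compound shows how these combine. In this assay an intermediate result is therefore expected, meaning an estimated step of a 22-fold higher number from compound 2 to compound 3 (1.35 log units; beyond the scatter) towards a higher number. For compound 3 the estimate is 100 nM with an expected range from 12 nM to 800 nM for this value.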

Compound 3, half-maximal effective concentration: 640 nM
The estimate for compound 3 lay 6.4-fold (0.81 log units) below the measured number, and the stated range covers the measured number.
By their numbers in this assay, from the lowest: compound 2; then compound 3; then compound 1.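

In this assay, chloro in place of hydrogen on the aromatic ring gives a 13-fold lower number from compound 1 to compound 3 (1.10 log units; beyond the scatter) and so shows that the phenyl group on this saturated ring carbon can gain from a second substituent. Yet 2,4-dichlorophenyl in place of 2-vinylphenyl gives a 140-fold higher number from compound 2 to compound 3 (2.16 log units; beyond the scatter), so this added chloro closes only part of the gap between compound 1 and compound 2. No experimental evidence here explains either step.

Still open, from the compounds shown here alone, is whether 2-methylphenyl or 2-ethylphenyl would match 2-vinylphenyl, or whether the vinyl double bond is needed.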